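A few compounds are considered here, and "the series" means these few. Any claim that something is new, unique, unknown or untested is made for them only; others in the source may bear on it.

Compound 1 `N#CCCCn1c(Cn2c(=O)n(-c3ccc(C(=O)O)cc3)c3ccncc32)cc2cc(Cl)ccc21`: > 50000 nM
Compound 2 `O=C(O)CCCn1c(Cn2c(=O)n(C3CC3)c3ccncc32)cc2cc(Cl)ccc21`: > 50000 nM
Compound 3 `CC1(n2c(=O)n(Cc3cc4cc(Cl)ccc4n3CCCS(C)(=O)=O)c3cnccc32)CC1`: > 50000 nM

Of the compounds shown here, three that share one core have been tested in an ADME assay on HeLa cells (Homo sapiens) for cytotoxicity, read by ATP content, with a stated time of 3 days; on this read-out lower numbers stand for higher toxicity in this test and higher numbers for lower toxicity in this test. Compound 1 gives > 50000 nM, which is a limit of the test and not a number. Compound 2 gives > 50000 nM, again a limit. Compound 3 gives > 50000 nM, also a limit. All three sit at the limit of > 50000 nM in this assay, at which 3 of the 3 values shown sit, so none of them can be told apart from the others, and compound 3 stands exactly where every measured compound stands. Within the data shown here, no two of them differ in only one place, so no step between measured compounds can be counted.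

Compound 4 `CS(=O)(=O)CCCn1c(Cn2c(=O)[nH]c3ccncc32)cc2cc(Cl)ccc21` has not yet been measured in this assay. It differs from compound 3 in one place: hydrogen in place of 1-methylcyclopropyl on an aromatic nitrogen. The 1-methylcyclopropyl leaves and a hydrogen enters on the aromatic nitrogen. Among the measured compounds shown here, nothing among the measured compounds shows what such a change does in this assay. Every measured value is a limit, and the shift a step that the limit leaves unreadable from compound 3 to compound 4 is expected to be none beyond the scatter. Compound 4 is expected to give about 70000 nM, between 30000 nM and 200000 nM, most likely again as a limit rather than a number.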

Compound 4, half-maximal cytotoxic concentration: > 50000 nM
Compound 4: a limit, no number (the forecaster's own chance of this, stated with the estimate: 85%); the middle value does not contradict the limit.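

Compound 3 and compound 4 both end at a limit of the test rather than a number, so no step can be read between them: the limit of > 50000 nM in this assay, at which 4 of the 4 values shown sit.

The compounds shown leave open at what concentration any of them would turn toxic to the cells, and whether hydrogen in place of 1-methylcyclopropyl changes that concentration.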